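The source may hold more compounds than are shown below. What is called first, only, known or untested is meant among the compounds shown, and "the series" means these compounds.

Of the compounds shown here, three sharing one core have been tested so far. Compound 1 `c1ccc(-c2cn3ccnc3c(-c3ccc4ncn(C5CCCCC5)c4c3)n2)cc1` carries a plain phenyl on the core; in a functional assay on NCI-H322M cells (Homo sapiens) for inhibition, read by sulforhodamine B assay, with a stated time of 48 h, tested at 10 uM (a higher number here means more inhibition at the concentration tested (going by the name of the read-out), a lower number less inhibition), compound 1 gives 5.25%. Compound 2 `COc1ccc(-c2cn3ccnc3c(-c3ccc4ncn(C5CCCCC5)c4c3)n2)cc1` adds a methoxy group to that phenyl, and compound 2 gives 31.5%. Compound 3 `c1ccc2c(-c3cn4ccnc4c(-c4ccc5ncn(C6CCCCC6)c5c4)n3)cccc2c1` carries a naphthalen-1-yl group instead, and compound 3 gives 4.74%, the lowest of the three numbers, although its gap to compound 1 lies within the scatter, as a number 0.5 percentage points lower from compound 1 to compound 3 (within the scatter) shows.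

Compound 4 `CC(=O)c1ccc(-c2cn3ccnc3c(-c3ccc4ncn(C5CCCCC5)c4c3)n2)cc1` is now to be measured. It differs from compound 3 in one place: 4-acetylphenyl in place of naphthalen-1-yl on an aromatic carbon

Going by the values given here, two measured steps bear on this. Adding a methoxy group to the phenyl gave a number 26.3 percentage points higher from compound 1 to compound 2 (beyond the scatter), while swapping the substituted phenyl for the naphthalen-1-yl group gave a number 26.8 percentage points lower from compound 2 to compound 3 (beyond the scatter). Compound 4 likewise returns to a single six-membered ring carrying a group at its far end, here an acetyl in place of a methoxy. A rise of modest size is therefore expected, a number 17.3 percentage points higher from compound 3 to compound 4 (beyond the scatter), mainly because the step of a number 26.3 percentage points higher from compound 1 to compound 2 (beyond the scatter) shows a substituted phenyl working better than an unsubstituted one. Going by these compounds, whether an acetyl behaves like a methoxy is unknown, so the range is wide. Compound 4 is estimated at 22%, between 5% and 42%.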

Compound 4, a percentage reported as inhibition, at one concentration (the size of the read-out at that concentration, not a potency): 1.19%
The estimate for compound 4 lay 20.8 percentage points above the measured number; measured number below the stated range.
By their numbers in this assay, from the lowest: compounds 4, 3 and 1 (each within the scatter of the next); then compound 2.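

A group on the phenyl does not by itself raise the number in this assay: with an acetyl there, the result stays level with the bare phenyl (a number 4.1 percentage points lower from compound 1 to compound 4 (within the scatter)) and with the naphthalen-1-yl group (a number 3.6 percentage points lower from compound 3 to compound 4 (within the scatter)). The identity of the group matters at this position, as acetyl in place of methoxy shows (a number 30.3 percentage points lower from compound 2 to compound 4 (beyond the scatter)), so among these four compounds only the methoxy of compound 2 stands clear of the rest, while compounds 1, 3 and 4 cannot be told apart. Nothing available explains why these two groups on the same phenyl give such different results.

Going by these compounds, whether the higher number belongs to methoxy alone remains open, and a hydroxyl, an ethoxy or an amine on the same phenyl would help to show how narrow that requirement is. On these data alone, all four numbers also come from a single concentration, so how these compounds would rank by potency is still unknown.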